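Swapping sec-butyl for an ester chain

This account rests on a few compounds, and the source may have more. Where it says the series, first, only, none or still open, it means among the compounds named here.

In a functional assay on MCF7 cells (Homo sapiens) for cytotoxicity, read by MTT assay, with a stated time of 24 h (on this read-out lower numbers stand for stronger inhibition and higher numbers for weaker inhibition), compound 1 `CC[C@H](C)[C@@H](NC(=O)Cn1cc(C2=C(c3c[nH]c4ccccc34)C(=O)N(C)C2=O)c2ccccc21)C(=O)OC` gives > 100000 nM, which is a limit of the assay and not a number. Compound 2 `COC(=O)[C@@H](CO)NC(=O)Cn1cc(C2=C(c3c[nH]c4ccccc34)C(=O)N(C)C2=O)c2ccccc21` gives 24500 nM. Among the measured compounds shown here, putting hydroxymethyl in place of sec-butyl produced an at least 4.0-fold lower number from compound 1 to compound 2 (0.61 log units; beyond the scatter), the only measured step that bears on the next change. Compound 3 `COC(=O)CC[C@@H](NC(=O)Cn1cc(C2=C(c3c[nH]c4ccccc34)C(=O)N(C)C2=O)c2ccccc21)C(=O)OC` instead has 2-(methoxycarbonyl)ethyl in place of sec-butyl on the same carbon: 2-(methoxycarbonyl)ethyl in place of sec-butyl on a saturated chain carbon bound to an amide-type nitrogen and a carbonyl carbon. The expected change, resting on that single step, is similar in size and direction, an at least 2.5-fold lower number from compound 1 to compound 3 (0.39 log units; beyond the scatter). For compound 3 the estimated value is 40000 nM, with an expected range of 12000 nM to 100000 nM.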

Compound 3, half-maximal inhibitory concentration: 23400 nM
Estimate against measurement, compound 3: 1.7-fold (0.23 log units) above; low and high end bracket the measured number.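

Putting 2-(methoxycarbonyl)ethyl in place of sec-butyl on the same carbon gave an at least 4.2-fold lower number from compound 1 to compound 3 (0.63 log units; beyond the scatter), so a second, larger oxygen-bearing group also moves the number away from that of compound 1. The two replacements do not separate, with a 1.0-fold lower number from compound 2 to compound 3 (0.02 log units; within the scatter), so this position tolerates both a hydroxymethyl and a 2-(methoxycarbonyl)ethyl group equally on this read-out. The first step has no upper size, since compound 1 stands at a limit of the assay: the limit of > 100000 nM in this assay, at which 1 of the 3 values shown sits.

From the compounds shown here alone, whether a plain methyl, an amine or a carboxylic acid on this carbon would give a different number remains open.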